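A pyrimidine ring replaces methoxyphenyl on the piperazine

The compounds below may be only part of what the source reports. "The series", "measured", "known", "first", "only" and "open" are said of these compounds alone.

Of the compounds shown here, two have numbers so far. Compound 1 `N#Cc1cccc(/C(CCN2CCN(c3ccccn3)CC2)=N/O)c1` gives 13.1 nM in a functional assay on HEK293 cells with D(4) dopamine receptor (Homo sapiens) as the target, read by FLIPR; a higher number here means that more compound is needed for the effect, a lower number that less compound is needed. Compound 2 `CCO/N=C(\CCN1CCN(c2ccccc2OC)CC1)c1ccccc1` gives 338 nM in this assay, the higher of the two numbers, and its gap to compound 1 lies beyond the scatter. Compound 3 `CCO/N=C(\CCN1CCN(c2ncccn2)CC1)c1ccccc1` differs from compound 2 in one place: pyrimidin-2-yl in place of 2-methoxyphenyl on an amine nitrogen in a ring. For the measured compounds named here, no measured pair shows this change on its own. A modest step to a lower number is expected from compound 2 to compound 3, a 2.3-fold lower number from compound 2 to compound 3 (0.35 log units; beyond the scatter), close to the scatter. Compound 3 is estimated at 150 nM, within 40 nM to 600 nM.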

Compound 3, half-maximal effective concentration: 615 nM
Estimate against measurement, compound 3: 4.1-fold (0.61 log units) below; the measured number lies above the stated range.
By their numbers in this assay, from the lowest: compound 1; then compounds 2 and 3 (each within the scatter of the next).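

In this assay placing pyrimidin-2-yl in place of 2-methoxyphenyl on the ring amine nitrogen gives a 1.8-fold higher number from compound 2 to compound 3 (0.26 log units; within the scatter) and so leaves the number unchanged in practical terms. On this core, therefore, an all-carbon aromatic ring bearing a methoxy group and an aromatic ring with two hetero atoms cannot be told apart at this position. No measured information accounts for this result. On these data alone, it remains open whether a plain phenyl or a 2-chlorophenyl group on that nitrogen would read the same, and whether this equivalence holds on the core of compound 1.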